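A Second Sulfur-Bearing Arm for Whole-Animal Inhibition

A few compounds are considered here, and "the series" means these few. Any claim that something is new, unique, unknown or untested is made for them only; others in the source may bear on it.

Of the compounds shown here, two have been tested in a functional assay on the whole organism for inhibition, with Rattus norvegicus as the target, at a dose of 30 mg/kg; a higher number here means more inhibition at the dose given (going by the name of the read-out), a lower number less inhibition. Compound 1, `C/N=C(\S)c1cccnc1N`, is the smaller of the two; in this assay compound 1 gives 27%. Compound 2, `C/N=C(\S)n1nc(-c2ccc(C)cc2)nc1N`, carries a larger ring system bearing a methyl-substituted phenyl ring; in this assay compound 2 gives 65%. On these two numbers compound 2 stands highest, and its nearest neighbour, compound 1, lies well behind it, a gap that goes beyond the usual scatter of the measurement.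

The next compound, compound 3, `C/N=C(\S)Nc1ccc(-c2nc(N)n(/C(S)=N/C)n2)cc1`, keeps everything in compound 2 except the methyl group, which is exchanged for a larger, sulfur-containing arm: a group of 5 heavy atoms (2 carbon, 2 nitrogen, 1 sulfur; no ring) in place of one carbon atom, on an aromatic carbon. Going by the values given here, no measured pair shows what such an exchange does, so the only guide is that compound 2 already sits at the high end of what has been seen. The expectation is therefore a step from compound 2 to compound 3 of a number 5 percentage points lower from compound 2 to compound 3 (within the scatter), small enough to fall within the scatter, in either direction. Compound 3 is estimated at 60%, with a range from 35% to 85%.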

Compound 3, a percentage reported as inhibition, in the whole organism at one dose (the size of the read-out at that dose, not a potency): 31%
Compound 3: the middle estimate sits 29 percentage points above what was measured, and the stated range ends above it.
By their numbers in this assay, from the lowest: compounds 1 and 3 (each within the scatter of the next); then compound 2.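

On the aromatic carbon para to a large group, the choice of substituent clearly matters: in this assay, replacing the methyl of compound 2 with the larger sulfur-containing arm gives a number 34 percentage points lower from compound 2 to compound 3 (beyond the scatter). Going by these compounds alone, this is the first measured exchange at this place, and it shows that this arm cannot stand in for the methyl without a large loss of inhibition at the dose given, even though the rest of the molecule stays the same. No measurement shown here explains the fall.

The arm differs from the methyl in several ways at once, including its size, its sulfur atom and its 2 hydrogen-bond donors and 1 hydrogen-bond acceptor, so this single pair cannot show which of these features, if any, accounts for the change. On these data alone, it also remains open whether the fall follows any departure from the methyl or belongs to this arm alone, a question that an ethyl group, a chlorine atom or a simple amine on the same aromatic carbon could help to answer.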